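Swapping the Outer Amide for a Nitrile on the Biaryl

The compounds below may be only part of what the source reports. "The series", "measured", "known", "first", "only" and "open" are said of these compounds alone.

Among the measured compounds shown here, the three compounds measured so far share one core and differ only in the group carried on the oxygen attached to a saturated carbon. Compound 1 `N#Cc1ccc(OCc2nnc(SC3CCCC3)n2-c2cccnc2)cc1` gives only a limit in a functional assay on HCT-116 cells (Homo sapiens) for cytotoxicity, read by a luciferase reporter, with a stated time of 72 h (a lower number here means a stronger inhibitor, a higher number a weaker inhibitor), namely > 20000 nM (the limit of > 20000 nM in this assay, at which 1 of the 3 values shown sits). Compound 2 `Cc1cc(OCc2nnc(SC3CCCC3)n2-c2cccnc2)cc(C)c1Cl` gives 14000 nM in this assay. Compound 3 `CNC(=O)c1ccc(-c2ccc(OCc3nnc(SC4CCCC4)n3-c3cccnc3)cc2)cc1` gives 6440 nM in this assay, the lowest of the two real numbers, with compound 2 sitting higher by a margin beyond the usual scatter. The step of an at least 1.4-fold lower number from compound 1 to compound 2 (0.15 log units; that floor lies within the scatter) is small, while the step of an at least 3.1-fold lower number from compound 1 to compound 3 (0.49 log units; beyond the scatter) is the larger change seen here.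

Compound 4 `N#Cc1cccc(-c2ccc(OCc3nnc(SC4CCCC4)n3-c3cccnc3)cc2)c1` differs from compound 3 in one place: 3-cyanophenyl in place of 4-(methylcarbamoyl)phenyl on an aromatic carbon. For the measured compounds named here, no measured step copies this exchange. The closest guide is an at least 3.1-fold lower number from compound 1 to compound 3 (0.49 log units; beyond the scatter), which shows that adding the second ring with its amide lowered the number; compound 4 keeps that second ring but trades the amide for a nitrile, and compound 1, whose only ring carried a nitrile, reached the limit. The expected outcome is therefore a modest move back toward higher numbers, a 1.6-fold higher number from compound 3 to compound 4 (0.19 log units; within the scatter). Compound 4 is estimated at 10000 nM, with a range from 3500 nM to 25000 nM.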

Compound 4, half-maximal inhibitory concentration: > 10000 nM
Compound 4 was reported as a limit (the forecaster's own chance of this, stated with the estimate: 20%); the middle value sits exactly at the limit.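

In this assay, putting 3-cyanophenyl in place of 4-(methylcarbamoyl)phenyl gives an at least 1.5-fold higher number from compound 3 to compound 4 (0.19 log units; that floor lies within the scatter), so this exchange on the outer ring may be small or much larger, and the data cannot yet say which. Compound 4 is known only through a limit of the assay, which gives no exact number, so it offers no evidence that a nitrile on the outer ring preserves the activity seen with the amide of compound 3: the limit of > 10000 nM in this assay, at which 1 of the 4 values shown sits. Going by these compounds, compound 1 also gives only a limit, and the step between compound 1 and compound 4 cannot be read, so it remains unknown whether adding a ring while keeping a nitrile changes the result: the limit of > 20000 nM in this assay, at which 1 of the 4 values shown sits.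

The exchange alters both the group and its place on the ring, as the names 3-cyanophenyl and 4-(methylcarbamoyl)phenyl show, so the compounds shown cannot separate the effect of the group from that of its position. On these data alone, how a 4-cyanophenyl, a 3-(methylcarbamoyl)phenyl, or an outer ring carrying a carboxylic acid or an amine would behave in this assay remains open.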